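This account rests on a few compounds, and the source may have more. Where it says the series, first, only, none or still open, it means among the compounds named here.

This account follows the step from compound 1 to compound 3. Compound 1, `Cc1scc(C[S+]([O-])C(c2ccccc2)c2ccccc2)c1C`, and compound 2, `[O-][S+](Cc1nc(O)cc(C(F)(F)F)n1)C(c1ccccc1)c1ccccc1`, were tested in an assay on HEK293 cells for inhibition of sodium-dependent dopamine transporter (Homo sapiens), read by scintillation counting, with stated times of 5 min and 1 min; a higher number here means a weaker inhibitor, a lower number a stronger inhibitor. In this assay compound 1 gives 284000 nM, the highest of the two numbers available. Compound 2 gives 40400 nM in this assay, a lower number that lies beyond the scatter. Compound 3, `[O-][S+](Cc1cc(C2CC2)on1)C(c1ccccc1)c1ccccc1`, has not yet been measured. It differs from compound 1 in one place: 5-cyclopropyl-1,2-oxazol-3-yl in place of 4,5-dimethylthiophen-3-yl on a saturated chain carbon bound to a sulfur. Among the compounds with values here, no step between measured compounds that differ in one place is available, so the size of the change can only be expected, not read off. Because compound 2 gives 40400 nM in this assay and compound 3 likewise brings a five-membered aromatic ring with 2 hetero atoms and 2 hydrogen-bond acceptors, compound 3 is expected to land at a lower number than compound 1. The expected step is a 2.8-fold lower number from compound 1 to compound 3 (0.45 log units; beyond the scatter), toward a stronger inhibitor. Compound 3 is estimated at 100000 nM, with a range from 30000 nM to 300000 nM.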

Compound 3, half-maximal inhibitory concentration: 38600 nM
Beside the measured number, compound 3's estimate is 2.6-fold (0.41 log units) above it; low and high end bracket the measured number.
By their numbers in this assay, from the lowest: compounds 3 and 2 (each within the scatter of the next); then compound 1.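

In this assay, within the data shown here, the change on a saturated chain carbon bound to a sulfur gives the first step that can be read at this place: a 7.4-fold lower number from compound 1 to compound 3 (0.87 log units; beyond the scatter). It shows that 5-cyclopropyl-1,2-oxazol-3-yl in place of 4,5-dimethylthiophen-3-yl moves the number toward a stronger inhibitor, though the step is modest and compound 3 remains a weak inhibitor, at a value within the scatter of compound 2. No data at hand bear on the cause of this step.

The ring and the cyclopropyl enter together, so the compounds shown leave open how much of the step belongs to each. As far as these compounds go, it also remains open how the number would respond to a methyl group or an amine in place of the cyclopropyl on the same ring.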